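The source may hold more compounds than are shown below. What is called first, only, known or untested is meant among the compounds shown, and "the series" means these compounds.

Compound 2 `CC#CCn1c(N2CCC[C@@H](N)C2)cc(=O)n(Cc2cccc(C(=O)OC)c2Br)c1=O` was tested in an assay on isolated protein for inhibition of Dipeptidyl peptidase 9 (Homo sapiens), read by fluorescence, with stated times of 15 min and 20 min; a higher number here means a weaker inhibitor, a lower number a stronger inhibitor. In this assay compound 2 gives > 100 nM, which is a limit of the assay rather than a number, and it sits at the limit of > 100 nM in this assay, at which 1 of the 2 values shown sits. Compound 1 `CC#CCn1c(N2CCC[C@@H](N)C2)cc(=O)n(Cc2cccc(C(=O)O)c2F)c1=O` has "not determined" (no result reported) in this assay. Compound 3 `CC#CCn1c(N2CCC[C@@H](N)C2)cc(=O)n(Cc2cccc(C(=O)OC)c2F)c1=O` differs from compound 2 by fluoro in place of bromo on an aromatic carbon. Among the measured compounds shown here, with no measured step of this kind to lean on, the change is expected to shift potency no further than the usual scatter, in either direction. Compound 3 is therefore estimated at 300 nM, between 100 nM and 3000 nM. That expectation corresponds to a step that the limit leaves unreadable from compound 2 to compound 3.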

Compound 3, half-maximal inhibitory concentration: > 100 nM
Compound 3 gave a limit, no number; the forecaster's own chance of this, stated with the estimate: 50%; the middle value is on the limit's open side.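

No step from bromo to fluoro can be read between compound 2 and compound 3, because both results are limits: the limit of > 100 nM in this assay, at which 2 of the 3 values shown sit.

The compounds shown leave open whether fluoro and bromo differ at all in this assay.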